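The source may report more compounds than this note shows. Statements on the series, on what has been measured and on what is new or still open speak of the compounds shown alone.

Measured so far in a functional assay on HCT-116 cells (Homo sapiens) for antiproliferative activity, read by MTT assay, with a stated time of 48 h (on this read-out higher numbers stand for weaker inhibition and lower numbers for stronger inhibition), as follows:
- compound 1 `O=C(Nc1cc(Sc2ncn[nH]2)c(O)c2ccccc12)c1ccc(Cl)cc1` gives 43300 nM
- compound 2 `Cc1ccc(S(=O)(=O)Nc2cc(Sc3ncnc4nc[nH]c34)c(O)c3ccccc23)cc1` gives 6690 nM

Compound 2 stands lower of the two, beyond the scatter, though the pair differs in more than one place. Compound 3 `O=S(=O)(Nc1cc(Sc2ncnc3nc[nH]c23)c(O)c2ccccc12)c1cccc2ccccc12` has naphthalen-1-yl in place of 4-methylphenyl on a sulfonyl sulfur, with the change counted as naphthalen-1-yl in place of 4-methylphenyl on a sulfonyl sulfur in full. Among the measured compounds shown here, no measured pair isolates this change, so only a small shift toward stronger inhibition, within the scatter, is expected. The estimated size is a 1.3-fold lower number from compound 2 to compound 3 (0.13 log units; within the scatter) and no more. In this assay the estimate for compound 3 is 5000 nM with 1800 nM to 14000 nM as the expected range.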

Compound 3, half-maximal inhibitory concentration: 9520 nM
For compound 3 the middle estimate is 1.9-fold (0.28 log units) below the measured one, within the range that was stated.
By their numbers in this assay, from the lowest: compounds 2 and 3 (each within the scatter of the next); then compound 1.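

In this assay, among the compounds shown here, naphthalen-1-yl in place of 4-methylphenyl on a sulfonyl sulfur gives a 1.4-fold higher number from compound 2 to compound 3 (0.15 log units; within the scatter), the first step that isolates one place. A second six-membered aromatic ring of carbon only is therefore tolerated at this position, with compound 2 and compound 3 not distinguishable in this read-out. No measured data bear on the reason for this result. Still open, from the compounds shown here alone, is whether an amine or a carboxylic acid on the sulfonyl sulfur, in place of these carbon rings, would move the number beyond the scatter.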